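Swapping a methoxyphenyl amide for a chlorophenyl amide

The compounds below may be only part of what the source reports. "The series", "measured", "known", "first", "only" and "open" are said of these compounds alone.

Measured compounds:
Compound 1, `O=C(NCc1ccccc1)c1c(O)c2cccnc2n(-c2ccccc2)c1=O`: 11.3%
Compound 2, `O=C(Nc1ccccc1)c1c(O)c2cccnc2n(-c2ccccc2)c1=O`: -15%
Compound 3, `COc1ccc(NC(=O)c2c(O)c3cccnc3n(-c3ccccc3)c2=O)cc1`: -1.9%

These three share one core and differ only in the group on the amide nitrogen. In a functional assay on the whole organism for inhibition, with Rattus norvegicus as the target, read by cytopathic effect and paw edema, at a dose of 100 mg/kg by the oral route (a lower number here means less inhibition, a higher number more inhibition at the dose given (going by the name of the read-out)), compound 3 stands second of the three, above compound 2 by a number 13.1 percentage points higher from compound 2 to compound 3 (beyond the scatter) and below compound 1 by a number 13.2 percentage points lower from compound 1 to compound 3 (beyond the scatter). Compound 4, `O=C(Nc1cccc(Cl)c1)c1c(O)c2cccnc2n(-c2ccccc2)c1=O`, is not yet measured; it differs from compound 3 by 3-chlorophenyl in place of 4-methoxyphenyl on an amide-type nitrogen. Among the compounds with values here, the step from compound 2 to compound 3 bears on this change in reverse, since the methoxy is lost; what the chlorine adds has no measured precedent here. A modest drop is therefore expected, roughly a number 4.1 percentage points lower from compound 3 to compound 4 (within the scatter). Compound 4 is estimated to give -6% in this assay, within -26% to 14%.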

Compound 4, a percentage reported as inhibition, in the whole organism at one dose (the size of the read-out at that dose, not a potency): 13.4%
Compound 4: the middle estimate sits 19.4 percentage points below what was measured; low and high end bracket the measured number.
By their numbers in this assay, from the lowest: compound 2; then compound 3; then compounds 1 and 4 (each within the scatter of the next).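

In this assay, chloro in place of hydrogen on an aromatic carbon raises the number (a number 28.4 percentage points higher from compound 2 to compound 4 (beyond the scatter)), and 3-chlorophenyl in place of 4-methoxyphenyl raises it too (a number 15.3 percentage points higher from compound 3 to compound 4 (beyond the scatter)). Compounds 2 and 3 sat under the benzyl amide, yet an aromatic ring directly on the amide nitrogen can match it (a number 2.1 percentage points higher from compound 1 to compound 4 (within the scatter)). Nothing available explains these differences. 

Going by these compounds, what 4-chlorophenyl, an aminophenyl or a carboxyphenyl would give on this nitrogen stays open. So does whether the gain follows the chlorine itself or its place on the ring.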